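Ring-nitrogen substituent: cyclohexyl in place of 2-fluorophenyl

A few compounds are considered here, and "the series" means these few. Any claim that something is new, unique, unknown or untested is made for them only; others in the source may bear on it.

In a functional assay on HeLa cells (Homo sapiens) for antiproliferative activity, read by CCK-8 assay, with a stated time of 72 h, tested at 2 uM (on this read-out lower numbers stand for a weaker effect and higher numbers for a stronger effect at the one concentration tested), compound 3 `Nc1ccccc1NC(=O)c1ccc(CSC(=S)N2CCN(c3ccccc3F)CC2)cc1` gives 17.5%, the second highest of the three numbers; compound 1 `Nc1ccccc1NC(=O)c1ccc(CSC(=S)N2CCN(Cc3ccccn3)CC2)cc1` gives 14.2% and compound 2 `Nc1ccccc1NC(=O)c1ccc(CSC(=S)N2CCN(c3ccccc3)CC2)cc1` gives 62.2%. Relative to compound 3 the measured steps are a number 3.3 percentage points higher from compound 1 to compound 3 (within the scatter) and a number 44.7 percentage points lower from compound 2 to compound 3 (beyond the scatter). Compound 4 `Nc1ccccc1NC(=O)c1ccc(CSC(=S)N2CCN(C3CCCCC3)CC2)cc1` differs from compound 3 by cyclohexyl in place of 2-fluorophenyl on an amine nitrogen in a ring. Every measured step concerns the group on the ring nitrogen: a number 48 percentage points higher from compound 1 to compound 2 (beyond the scatter) and a number 44.7 percentage points lower from compound 2 to compound 3 (beyond the scatter) were large, whereas a number 3.3 percentage points higher from compound 1 to compound 3 (within the scatter) stayed within the scatter. Within the data shown here, none of them brings in a non-aromatic ring, so there is no direct precedent for cyclohexyl at this position. The read-out has moved widely with this group. A step in either direction is therefore possible. Compound 4 is estimated at 25%, in a range from 5% to 60%. That estimate means an expected step of a number 7.5 percentage points higher from compound 3 to compound 4 (within the scatter).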

Compound 4, a percentage reported as inhibition, at one concentration (the size of the read-out at that concentration, not a potency): 30.6%
Beside the measured number, compound 4's estimate is 5.6 percentage points below it; the range from low to high includes it.
By their numbers in this assay, from the lowest: compounds 1 and 3 (each within the scatter of the next); then compound 4; then compound 2.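

Cyclohexyl puts a non-aromatic ring on the ring nitrogen for the first time: the change gives a number 13.1 percentage points higher from compound 3 to compound 4 (beyond the scatter) and a number 16.4 percentage points higher from compound 1 to compound 4 (beyond the scatter), but also a number 31.6 percentage points lower from compound 2 to compound 4 (beyond the scatter). An aromatic ring at this position is therefore not required for a number above the two lowest in the series, although phenyl still gives the highest number of the four. Nothing available explains these differences.

Still open, on these data alone, is how a methyl group or a longer alkyl chain on the ring nitrogen would compare. Also open, as far as these compounds go, is the effect of a hydroxyl or an amine on the cyclohexyl ring.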